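Swapping an Amide for an Oxadiazole on a Shared Core

The compounds below may be only part of what the source reports. "The series", "measured", "known", "first", "only" and "open" are said of these compounds alone.

Measured so far in a physicochemical assay for solubility, using the shake flask method, in simulated intestinal fluid, measured as kinetic solubility, with a stated time of 2 h, at 25 degrees C, at pH 6.5 (a lower number here means a less soluble compound, a higher number a more soluble compound), are three compounds:
- compound 1 `Cc1nc(C(=O)O)c(N)c2c1C(=O)N(Cc1ccccc1)C2=O` gives 177000 nM
- compound 2 `Cc1nc(C(=O)OC2CC2)c(N)c2c1C(=O)N(Cc1ccccc1)C2=O` gives 202000 nM
- compound 3 `CNC(=O)c1nc(C)c2c(c1N)C(=O)N(Cc1ccccc1)C2=O` gives 41000 nM

Compound 3 has the lowest number of the three. Compound 4 `Cc1nnc(-c2nc(C)c3c(c2N)C(=O)N(Cc2ccccc2)C3=O)o1` differs from it in one place, with 5-methyl-1,3,4-oxadiazol-2-yl in place of methylcarbamoyl on an aromatic carbon and the rest of the core unchanged.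

Within the data shown here, three measured steps concern this same carbon. The change a 4.3-fold lower number from compound 1 to compound 3 (0.64 log units; beyond the scatter) and the change a 4.9-fold lower number from compound 2 to compound 3 (0.69 log units; beyond the scatter) are both modest but beyond the scatter, whereas the change a 1.1-fold higher number from compound 1 to compound 2 (0.06 log units; within the scatter) stays within it. None of these compounds carries an aromatic ring at this carbon, so the steps offer only a rough guide to size and little guide to direction. The expected move is therefore none beyond the scatter, an estimated 1.5-fold higher number from compound 3 to compound 4 (0.17 log units; within the scatter) in this assay as the central guess. Compound 4 is estimated at 60000 nM with an expected range of 15000 nM to 200000 nM for this measurement.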

Compound 4, solubility: < 5000 nM
Compound 4: only a limit was reported; the forecaster's own chance of this, stated with the estimate: 5%; at least 12-fold (1.07 log units) between middle value and limit.
By their numbers in this assay, from the lowest: compound 3; then compounds 1 and 2 (each within the scatter of the next). At a limit, below all of these: compound 4.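

In this assay, compound 4 reaches only a limit of the assay, not a number: the limit of < 5000 nM in this assay, at which 1 of the 4 values shown sits.

Among these compounds, putting 5-methyl-1,3,4-oxadiazol-2-yl in place of methylcarbamoyl gives an at least 8.2-fold lower number from compound 3 to compound 4 (0.91 log units; beyond the scatter), whereas the earlier steps at this carbon stayed modest or within the scatter. Among the compounds shown here, the same group gives an at least 35-fold lower number from compound 1 to compound 4 (1.54 log units; beyond the scatter) and an at least 40-fold lower number from compound 2 to compound 4 (1.60 log units; beyond the scatter), both large, which shows that an aromatic ring at this carbon, absent from all the earlier compounds, can take the number well down.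

The compounds shown do not separate the effect of the ring itself from that of its methyl group, and the full size of each step stays unknown. An amine in place of that methyl, or a ring with a carboxylic acid on it, would test whether the low number holds.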